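Cyanoacrylic acids on the shared core: amino for bromo

This account rests on a few compounds, and the source may have more. Where it says the series, first, only, none or still open, it means among the compounds named here.

Measured compounds:
compound 1, `N#C/C(=C\c1ccc(Br)cc1)C(=O)O`: 500 nM
compound 2, `CCCCCCN(CCCCCC)c1ccc(/C=C(\C#N)C(=O)O)cc1`: 880 nM
compound 3, `C=CCN(CC=C)c1ccc(/C=C(\C#N)C(=O)O)cc1`: 110 nM

All three were run in an assay on RBE4 cells for inhibition of Monocarboxylate transporter 1 (Rattus norvegicus), with a stated time of 15 min; on this read-out higher numbers stand for weaker inhibition and lower numbers for stronger inhibition. Compound 1 stands second highest of the three numbers. Its nearest neighbour is compound 2, whose number is higher but within the scatter; its furthest is compound 3, whose number is lower by an amount beyond the scatter.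

The next compound on the same core is compound 4, `N#C/C(=C\c1ccc(N2CCCCC2)cc1)C(=O)O`. It differs from compound 1 in one place: piperidin-1-yl in place of bromo on an aromatic carbon. Compound 4 thus carries a cyclic amine where compound 1 carries a halogen, and it sits between compound 2 (dihexylamino) and compound 3 (diallylamino) in the size of the nitrogen substituent.

Among the measured compounds shown here, no measured pair in this set reproduces this exact change, so the expectation rests on the two amino-substituted analogues. Compound 2 gives a number close to compound 1, while compound 3 gives a clearly lower one; a modest move downward, toward stronger inhibition, is expected for compound 4, of a size that may or may not clear the scatter. The expected step from compound 1 to compound 4 is a 2.0-fold lower number from compound 1 to compound 4 (0.30 log units; within the scatter). Compound 4 is estimated at 250 nM, with a range of 60 nM to 1000 nM.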

Compound 4, half-maximal inhibitory concentration: 140 nM
Compound 4: middle estimate off by 1.8-fold (0.25 log units), on the high side; measured number inside the range.
By their numbers in this assay, from the lowest: compounds 3 and 4 (each within the scatter of the next); then compounds 1 and 2 (each within the scatter of the next).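

In this assay, among the compounds shown here, the change from bromo to piperidin-1-yl is the first confined to one place, and it gives a 3.6-fold lower number from compound 1 to compound 4 (0.55 log units; beyond the scatter) as a step beyond the scatter. This position, on an aromatic carbon para to a group of 7 heavy atoms, therefore takes a six-membered non-aromatic ring with its nitrogen in place of a single bromine, and the number moves toward stronger inhibition rather than weaker. Compound 4 at 140 nM and compound 3 at 110 nM lie within the scatter of each other, so a cyclic amine and the open diallylamino group read alike here, while nothing measured in this set bears on the reason for the step.

Still open, from the compounds shown here alone, is whether the step follows the attached nitrogen or the ring carbons, a question that a cyclohexyl group at this place would address. Pyrrolidin-1-yl and morpholin-4-yl would show how far the ring itself can change, and a small dimethylamino group would show whether any ring or longer chain on the nitrogen is needed at all.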